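A few compounds are considered here, and "the series" means these few. Any claim that something is new, unique, unknown or untested is made for them only; others in the source may bear on it.

Working notes on the triazole series.

Compound 1, `C=C1C(=O)[C@]23C[C@@]1(O)CC[C@H]2c1ccc(OS(=O)(=O)c2ccc(C)cc2)c(C)c1[C@@H]3Cn1cc(-c2ccc(Cl)cc2)nn1`, gives 1260 nM in a functional assay on HL-60 cells (Homo sapiens) for cytotoxicity, read by MTT assay, with a stated time of 4 days; a lower number here means a stronger inhibitor, a higher number a weaker inhibitor. Compound 2, `C=C1C(=O)[C@]23C[C@@]1(O)CC[C@H]2c1ccc(OS(=O)(=O)c2ccc(C)cc2)c(C)c1[C@@H]3Cn1cc(-c2ccc(C)cc2)nn1`, gives 1110 nM in this assay. Going by the values given here, the single change between them, (chloro in place of methyl on an aromatic carbon), produces a 1.1-fold higher number from compound 2 to compound 1 (0.06 log units; within the scatter), so the two values are read as equal within the scatter.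

Compound 3, `C=C1C[C@]23C[C@@]1(O)CC[C@H]2c1cc(Br)c(O)c(C)c1[C@@H]3Cn1cc(-c2ccc(C)cc2)nn1`, carries a different core. How the core of compound 3 differs from that of compound 2 is not broken down here. For compound 3 this assay reports only a limit, > 20000 nM. That limit is the limit of > 20000 nM in this assay, at which 1 of the 3 values shown sits.

Compound 4, `C=C1C[C@]23C[C@@]1(O)CC[C@H]2c1cc(Br)c(O)c(C)c1[C@@H]3Cn1cc(-c2ccc(Cl)cc2)nn1`, is not yet measured. It differs from compound 3 by chloro in place of methyl on an aromatic carbon, the same change that carries compound 2 to compound 1, at the same place: on an aromatic carbon of a six-membered aromatic ring of carbon only, para to a large group.

The step is expected to be a step that the limit leaves unreadable from compound 3 to compound 4, resting on the measured 1.1-fold higher number from compound 2 to compound 1 (0.06 log units; within the scatter), which stayed within the scatter. Compound 4 is therefore expected to sit near the limit of compound 3 in this assay, and most likely to be reported as a limit again. The estimate for compound 4 is 25000 nM, with a range from 10000 nM to 60000 nM.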

Compound 4, half-maximal inhibitory concentration: 5590 nM
The estimate for compound 4 lay 4.5-fold (0.65 log units) above the measured number, and the stated range ends above it.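

In this assay, the change from 4-methylphenyl to 4-chlorophenyl gives an at least 3.5-fold lower number from compound 3 to compound 4 (0.55 log units; beyond the scatter), so a step that was flat on the core of compound 2 does not carry over unchanged to the core of compound 3: the same change on two cores in this assay, a 1.1-fold higher number (0.06 log units; within the scatter) from compound 2 to compound 1 and an at least 3.5-fold lower number (0.55 log units; beyond the scatter) from compound 3 to compound 4, at least 4.0-fold (0.60 log units) apart, beyond the scatter of two such steps

The size of the new step is only a bound, as compound 3 is known only as a limit: the limit of > 20000 nM in this assay, at which 1 of the 4 values shown sits.

Which of the differences between the two cores accounts for the gap is not shown, and two cores give no rule for how this change will behave on a third.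

Open, from the compounds shown here alone, is the true size of the step on the core of compound 3, and how the 4-chlorophenyl group behaves on a core that carries only some of the differences between these two cores. Also open, going by these compounds, is whether a methoxy group or an amine in place of the chloro on that aromatic ring would follow the pattern of either core.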